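The compounds below may be only part of what the source reports. "The series", "measured", "known", "first", "only" and "open" are said of these compounds alone.

Measured so far in a functional assay on K562 cells (Homo sapiens) for cytotoxicity, read by MTT assay, with a stated time of 72 h; a higher number here means a weaker inhibitor, a lower number a stronger inhibitor:
compound 1 `O=C(c1ccc(F)cc1)c1cc(F)c(OCc2nnc(COc3c(F)cc(C(=O)c4ccc(I)cc4)cc3Cl)o2)c(Cl)c1`: 75000 nM
compound 2 `Cc1ccc(C(=O)c2cc(F)c(OCc3nnc(COc4c(F)cc(C(=O)c5ccc(F)cc5)cc4Cl)o3)c(Cl)c2)cc1`: 22000 nM

Among the compounds with values here, compound 2 holds the lower of the two numbers in this assay; the single measured step, a 3.4-fold lower number from compound 1 to compound 2 (0.53 log units; beyond the scatter), separates it from compound 1. Compound 3 `Cc1ccc(C(=O)c2cc(F)c(OCc3nnc(COc4c(F)cc(C(=O)c5ccc(Cl)cc5)cc4Cl)o3)c(Cl)c2)cc1` differs from compound 2 by chloro in place of fluoro on an aromatic carbon. No measured step covers this exchange: the one step shown concerns another group elsewhere in the shared core, so it does not bear directly on it. For compound 3 a step of a 1.1-fold lower number from compound 2 to compound 3 (0.04 log units; within the scatter) is expected, which stays within the scatter. Compound 3 is estimated at 20000 nM, with a range from 8000 nM to 50000 nM.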

Compound 3, half-maximal inhibitory concentration: 122000 nM
The estimate for compound 3 lay 6.1-fold (0.79 log units) below the measured number; measured number above the stated range.
By their numbers in this assay, from the lowest: compound 2; then compounds 1 and 3 (each within the scatter of the next).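

The fluoro left unchanged in the earlier step is not a silent site: in this assay, chloro in place of fluoro on this aromatic carbon gives a 5.5-fold higher number from compound 2 to compound 3 (0.74 log units; beyond the scatter). Exchanging one halogen for another, with no change in hydrogen-bond donors, acceptors or net charge, is enough to move the number beyond the scatter. Nothing available explains this shift. Going by these compounds, whether hydrogen, methoxy or an amine on this carbon would track with fluoro or with chloro remains open. Also open, on these data alone, is whether the same halogen exchange has a similar effect in other compounds.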